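Cytotoxicity on MT4 cells: three limits and one estimate

The compounds below may be only part of what the source reports. "The series", "measured", "known", "first", "only" and "open" are said of these compounds alone.

The measured compounds and their readings in an ADME assay on MT4 cells (Homo sapiens) for cytotoxicity, read by MTT assay; on this read-out higher numbers stand for lower toxicity in this test and lower numbers for higher toxicity in this test:
compound 1 `O=C(CSc1nnnn1-c1cccc2ccccc12)N/N=C/c1cccs1` — a limit of > 316000 nM
compound 2 `O=C(CSc1nnnn1-c1cccc2ccccc12)N/N=C/c1ccccc1F` — a limit of >= 118000 nM
compound 3 `O=C(CSc1nnnn1-c1cccc2ccccc12)N/N=C/c1ccc(F)cc1` — a limit of > 307000 nM

Compound 3 stands at a limit of the assay, not at a number. The same holds for the other two compounds, as the limit of > 307000 nM in this assay, at which 1 of the 3 values shown sits, the limit of > 316000 nM in this assay, at which 1 of the 3 values shown sits, and the limit of >= 118000 nM in this assay, at which 1 of the 3 values shown sits, show, so all three values shown are limits. The steps a step that the two limits leave unreadable from compound 1 to compound 3, a step that the two limits leave unreadable from compound 2 to compound 3 and a step that the two limits leave unreadable from compound 1 to compound 2 therefore cannot be read in size.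

Compound 4 `O=C(CSc1nnnn1-c1cccc2ccccc12)N/N=C/c1ccc(O)cc1` differs from compound 3 by hydroxy in place of fluoro on an aromatic carbon. For the measured compounds named here, no measured step exchanges fluoro for hydroxy, and no measured step has a readable size, so none of them bears directly on this change. What the three limits do show is that the whole series sits at the top of the readable range in this assay, and nothing in the data points to a departure from that for compound 4.

Compound 4 is therefore expected to stay at a limit, with an estimated step of an at least 1.0-fold lower number from compound 3 to compound 4 (0.01 log units; that floor lies within the scatter) that means no change beyond the scatter. The estimate for compound 4 is 300000 nM, with a range from 100000 nM to 1000000 nM.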

Compound 4, half-maximal cytotoxic concentration: > 309000 nM
Compound 4: no number, only a limit; the forecaster's own chance of this, stated with the estimate: 80%; middle value at least 1.0-fold (0.01 log units) away from the limit.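

In this assay compound 4 gives > 309000 nM, which is a limit and not a number. Compound 1, compound 2 and compound 3 also stand at limits, so the steps from each of them to compound 4 cannot be read in size. The compounds shown leave open whether hydroxy in place of fluoro, or any other change among them, alters the read-out at all.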